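Aminopyrimidine series: aryl to arylmethyl swap on the ring nitrogen

The source may report more compounds than this note shows. Statements on the series, on what has been measured and on what is new or still open speak of the compounds shown alone.

Compound 1 `Cn1c(=O)c(S(=O)(=O)c2ccc(F)cc2F)cc2cnc(Nc3ccc4[nH]ncc4c3)nc21` gives 50000 nM in a functional assay on K562 cells (Homo sapiens) for inhibition, read by trypan blue exclusion, with a stated time of 72 h; on this read-out lower numbers stand for stronger inhibition and higher numbers for weaker inhibition. Compound 2 `Cn1c(=O)c(S(=O)(=O)c2ccc(F)cc2F)cc2cnc(Nc3ccncn3)nc21` gives 30000 nM, the lowest of the two numbers in this assay, with compound 1 within the scatter of it. For the measured compounds named here, the only measured step, a 1.7-fold lower number from compound 1 to compound 2 (0.22 log units; within the scatter), exchanged one aromatic ring for another and did not move the number beyond the scatter. Compound 3 `Cn1c(=O)c(S(=O)(=O)c2ccc(F)cc2F)cc2cnc(NCc3ccc4[nH]ccc4c3)nc21` differs from compound 2 by (1H-indol-5-yl)methyl in place of pyrimidin-4-yl on a nitrogen on an aromatic ring. Going by the values given here, no measured step covers a change of this kind, so no shift beyond the scatter is expected; compound 3 is estimated at 30000 nM (range 8000 nM to 100000 nM), a step of no change at the digits printed from compound 2 to compound 3 (within the scatter) that is expected to stay within the scatter.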

Compound 3, half-maximal inhibitory concentration: 75000 nM
Beside the measured number, compound 3's estimate is 2.5-fold (0.40 log units) below it, within the range that was stated.
By their numbers in this assay, from the lowest: compounds 2, 1 and 3 (each within the scatter of the next, the first and the last beyond it).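

In this assay, for the compounds shown here, (1H-indol-5-yl)methyl on the nitrogen gives the first step beyond the scatter, though a modest one (a 2.5-fold higher number from compound 2 to compound 3 (0.40 log units; beyond the scatter)). Measured against the 1H-indazol-5-yl group, the same change stays within the scatter (a 1.5-fold higher number from compound 1 to compound 3 (0.18 log units; within the scatter)), so the position shows no clear shift from this group across all pairs. Nothing available here explains the step.

On these data alone, because ring and methyl link change together in compound 3, their separate contributions remain open. Also open, as far as these compounds go, is how a morpholine or a longer alkyl chain would read on this nitrogen.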